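The source may hold more compounds than are shown below. What is called first, only, known or untested is meant among the compounds shown, and "the series" means these compounds.

Measured in a functional assay on HepG2 cells (Homo sapiens) for cytotoxicity, read by MTT assay, with a stated time of 24 h; on this read-out higher numbers stand for weaker inhibition and lower numbers for stronger inhibition:

compound 1, `Fc1ccc(-c2n[nH]cc2/C=N/n2c(OCc3ccccc3Cl)n[nH]c2=S)cc1`: 71 ug/mL
compound 2, `S=c1[nH]nc(OCc2ccccc2)n1/N=C/c1c[nH]nc1-c1ccc(Cl)cc1`: 18 ug/mL
compound 3, `Cc1ccc(COc2nn(CN(c3ccccc3)c3ccccc3)c(=S)n2/N=C/c2c[nH]nc2-c2ccc(F)cc2)cc1`: 90 ug/mL

Compound 3 stands highest of the three numbers. Compound 1 lies within the scatter of compound 3, so no order between the two can be read. Among the compounds with values here, compound 2 lies beyond the scatter, with the lower number, and is the only compound of the three that is clearly separated from compound 3.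

Compound 4, `Cc1ccc(COc2nn(CN(c3ccccc3)c3ccccc3)c(=S)n2/N=C/c2c[nH]nc2-c2ccc(Cl)cc2)cc1`, differs from compound 3 in one place: chloro in place of fluoro on an aromatic carbon. Within the data shown here, no measured pair differs only in this way. Among the measured compounds shown here, compound 1 and compound 2 carry fluoro and chloro at the corresponding place, but they differ elsewhere as well, so their two values show only that compound 2 gives the lower number and allow no step to be drawn.

In this assay the step from compound 3 to compound 4 is therefore expected to be small, toward a lower number, and it may not reach beyond the scatter: a 1.5-fold lower number from compound 3 to compound 4 (0.18 log units; within the scatter). For compound 4 the estimated value is 60 ug/mL, with a range from 25 ug/mL to 130 ug/mL.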

Compound 4, half-maximal inhibitory concentration: 97 ug/mL
Compound 4: middle estimate off by 1.6-fold (0.21 log units), on the low side; the range from low to high includes it.
By their numbers in this assay, from the lowest: compound 2; then compounds 1, 3 and 4 (each within the scatter of the next).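

Working notes on the series: in this assay, the first matched pair at this position, chloro in place of fluoro on the six-membered aromatic ring of carbon only gives a 1.1-fold higher number from compound 3 to compound 4 (0.03 log units; within the scatter). With the rest of the structure held constant, the read-out therefore does not distinguish 4-fluorophenyl from 4-chlorophenyl on this 1H-pyrazol-4-yl attachment, and this pair gives no ground for treating the halogen exchange as a route to a lower number. Nothing available explains this outcome.

As far as these compounds go, whether a methoxy group, a nitrile, a dimethylamino group or a carboxylic acid at this place would move the number beyond the scatter remains open. Also open, from the compounds shown here alone, is whether the same halogen exchange would read alike on the core of compound 2, which lacks the further substituents of compound 4.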